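Demethylation of the aminoethyl side chain in the curcuminoid series

The source may hold more compounds than are shown below. What is called first, only, known or untested is meant among the compounds shown, and "the series" means these compounds.

Compound 1 `COc1cc(/C=C/C(=O)/C=C(/C=C/c2ccc(O)c(OC)c2)NCCO)ccc1O` gives 103% in a functional assay on Caco-2 cells (Homo sapiens) for activation, read by fluorescence, tested at 1 uM; on this read-out higher numbers stand for a weaker effect at the one concentration tested and lower numbers for a stronger effect. Compound 2 `COCCNC(=C\C(=O)/C=C/c1ccc(O)cc1)/C=C/c1ccc(O)cc1` gives 94.9% in this assay, and compound 3 `COCCNC(=C\C(=O)/C=C/c1ccc(O)c(OC)c1)/C=C/c1ccc(O)c(OC)c1` gives 105%. The difference between the cores of compound 2 and compound 3 is not broken down here. Within the measured set, the change hydrogen in place of methyl on an oxygen on a saturated carbon gives a number 2 percentage points lower from compound 3 to compound 1 (within the scatter). Compound 4 `O=C(/C=C(/C=C/c1ccc(O)cc1)NCCO)/C=C/c1ccc(O)cc1`, not yet measured, carries the same change relative to compound 2: hydrogen in place of methyl on an oxygen on a saturated carbon. The change occurs twice among the compounds shown, each time at the same place. The step from compound 2 to compound 4 is expected to be a number 1.9 percentage points lower from compound 2 to compound 4 (within the scatter) in this assay, an expectation that rests on a number 2 percentage points lower from compound 3 to compound 1 (within the scatter). On that basis compound 4 is estimated at 93%, with a range from 82% to 104%.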

Compound 4, a percentage reported as activity, at one concentration (the size of the read-out at that concentration, not a potency): 98.1%
For compound 4 the middle estimate is 5.1 percentage points below the measured one; the range from low to high includes it.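

In this assay, 2-hydroxyethyl in place of 2-methoxyethyl gives a number 3.2 percentage points higher from compound 2 to compound 4 (within the scatter), so the step on this core is as small as the earlier one. Carried from one core to the other, the change shows no difference that this read-out can resolve: the same change on two cores in this assay, a number 2 percentage points lower (within the scatter) from compound 3 to compound 1 and a number 3.2 percentage points higher (within the scatter) from compound 2 to compound 4, 5.2 percentage points apart, within the scatter of two such steps

This supports only a small step on both cores at the one concentration tested; it gives no potency and does not show that a larger effect of the change would carry over.

The compounds shown all carry 2-hydroxyethyl or 2-methoxyethyl, so whether this assay responds to this side chain at all remains open. An amine or a carboxylic acid at the end of the chain, or a longer chain, would test that.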